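Three ketones at the cytotoxicity limit, a fourth expected there

The source may hold more compounds than are shown below. What is called first, only, known or untested is meant among the compounds shown, and "the series" means these compounds.

Compound 1 `CC(=O)c1ccn(-c2ccc3c(c2)B(O)OC3)c1` gives > 10 ug/mL in an ADME assay on L929 cells (Mus musculus) for cytotoxicity, read by resazurin assay, with a stated time of 72 h (on this read-out lower numbers stand for stronger inhibition and higher numbers for weaker inhibition), a limit of the assay rather than a number.
Compound 2 `O=C(c1ccn(-c2ccc3c(c2)B(O)OC3)c1)c1ccc(Cl)cc1Cl` gives > 10 ug/mL in this assay, again a limit.
Compound 3 `Cc1ccc(C(=O)c2ccn(-c3ccc4c(c3)B(O)OC4)c2)cc1` gives > 10 ug/mL in this assay, also a limit.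

Compound 3 therefore stands only at a limit, and all three values sit at the limit of > 10 ug/mL in this assay, at which 3 of the 3 values shown sit. The measured steps a step that the two limits leave unreadable from compound 1 to compound 2, a step that the two limits leave unreadable from compound 1 to compound 3 and a step that the two limits leave unreadable from compound 2 to compound 3 are each unreadable, so no size and no direction can be taken from them. Compound 4 `COc1ccccc1C(=O)c1ccn(-c2ccc3c(c2)B(O)OC3)c1` differs by 2-methoxyphenyl in place of 4-methylphenyl on a carbonyl carbon. With every related step unreadable, the step that the limit leaves unreadable from compound 3 to compound 4 is expected to show nothing beyond the scatter. Compound 4 is therefore estimated at 15 ug/mL in this assay, within 7 ug/mL to 40 ug/mL, most likely reported again only as a limit.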

Compound 4, half-maximal inhibitory concentration: > 10 ug/mL
Compound 4: no number, only a limit; the forecaster's own chance of this, stated with the estimate: 80%; the middle value lies beyond the limit too.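

Compound 4 also stands only at a limit, so no step between it and compound 1, compound 2 or compound 3 can be read, and all four compounds share one limit: the limit of > 10 ug/mL in this assay, at which 4 of the 4 values shown sit.

The compounds shown leave open whether any of the four differs from the others in this assay.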